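The source may report more compounds than this note shows. Statements on the series, on what has been measured and on what is new or still open speak of the compounds shown alone.

Measured compounds in an ADME assay on HPC cells (Homo sapiens) for cytotoxicity, with a stated time of 48 h; a higher number here means that more compound is tolerated, a lower number that less compound is tolerated:
- Compound 1, `COc1ccc(/C=C/C(=O)c2c(C)[n+]([O-])c3ccccc3[n+]2[O-])cc1OC`: compound 1 gives 142000 nM
- Compound 2, `Cc1c(C(=O)/C=C/c2ccc(Br)cc2)[n+]([O-])c2ccccc2[n+]1[O-]`: compound 2 gives 43000 nM
- Compound 3, `Cc1c(C(=O)/C=C/c2cccc([N+](=O)[O-])c2)[n+]([O-])c2ccccc2[n+]1[O-]`: compound 3 gives 46000 nM

The three measured compounds share one core and differ only in the aryl ring attached to the unsaturated ketone. Compound 2 stands at the lowest of the three numbers in this assay, but its nearest neighbour, compound 3, lies within the usual scatter of it, so the two cannot be told apart; only compound 1 stands clearly higher, beyond the scatter. For the measured compounds named here, no single-point steps between measured compounds are available, so the picture rests on these three values alone.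

Compound 4, `Cc1ccc(/C=C/C(=O)c2c(C)[n+]([O-])c3ccccc3[n+]2[O-])cc1`, has not yet been measured in this assay. It differs from compound 2 by methyl in place of bromo on an aromatic carbon. Given that compound 2 gives 43000 nM and that the one clearly higher number belongs to compound 1 with its dimethoxyphenyl, the step from compound 2 to compound 4 is expected to be small, at most a modest rise, and may well stay within the scatter: a 1.4-fold higher number from compound 2 to compound 4 (0.14 log units; within the scatter). Compound 4 is therefore estimated at 60000 nM, with a range from 25000 nM to 140000 nM.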

Compound 4, half-maximal cytotoxic concentration: 40000 nM
Beside the measured number, compound 4's estimate is 1.5-fold (0.18 log units) above it; measured number inside the range.
By their numbers in this assay, from the lowest: compounds 4, 2 and 3 (each within the scatter of the next); then compound 1.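

In this assay, for the compounds shown here, the first step that changes only one place, methyl in place of bromo on an aromatic carbon para to a large group, gives a 1.1-fold lower number from compound 2 to compound 4 (0.03 log units; within the scatter) and so leaves the two compounds indistinguishable. Going by these compounds alone, this single-place comparison shows that the measurement does not separate these two groups at this position, which the earlier compounds, with no such pair among them, could not show. Nothing measured here accounts for this result.

Going by these compounds, whether an amine or a carboxylic acid at this same position would give a number distinct from those of these two groups remains open. Compound 1, with its dimethoxyphenyl, gives 142000 nM, and the compounds shown do not reveal which part of that ring goes with this value.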